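This account rests on a few compounds, and the source may have more. Where it says the series, first, only, none or still open, it means among the compounds named here.

In a physicochemical assay for lipophilicity, at pH 7.4 (a lower number here means a more polar compound, a higher number a more lipophilic compound), compound 2 `COc1cccc2[nH]c(C)c(Cc3ccccc3)c(=O)c12` gives 2.11 and compound 1 `Cc1[nH]c2ccccc2c(=O)c1Cc1ccccc1` gives 1.93, so the two lie within the scatter of each other. Compound 3 `Cc1[nH]c2cccc(Cl)c2c(=O)c1Cc1ccccc1` carries chloro in place of methoxy on an aromatic carbon. Within the data shown here, the only measured step bearing on this change is methoxy in place of hydrogen on an aromatic carbon, a number 0.18 log units higher from compound 1 to compound 2 (within the scatter). Among the measured compounds shown here, no measured step involves chloro, so the expectation rests on the structural change alone. A modest rise is expected in this assay, with an estimated step of a number 0.39 log units higher from compound 2 to compound 3 (beyond the scatter). Compound 3 is estimated at 2.5, with an expected range of 2.15 to 2.9.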

Compound 3, distribution coefficient: 2.65
Beside the measured number, compound 3's estimate is 0.15 log units below it; the measured number falls inside the stated range.
By their numbers in this assay, from the lowest: compounds 1 and 2 (each within the scatter of the next); then compound 3.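

In this assay, among these compounds, chloro on this aromatic carbon gives the first steps beyond the scatter: a number 0.72 log units higher from compound 1 to compound 3 (beyond the scatter) for chloro in place of hydrogen, and a number 0.54 log units higher from compound 2 to compound 3 (beyond the scatter) for chloro in place of methoxy. The position therefore responds to substitution, although methoxy in place of hydrogen gave only a number 0.18 log units higher from compound 1 to compound 2 (within the scatter) here. Nothing available accounts for these steps.

Still open, as far as these compounds go, is where an amine or a carboxylic acid on the same aromatic carbon would fall. Also open, from the compounds shown here alone, is whether chloro elsewhere on the shared core would give a similar step.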